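Compound 2 and its rearranged partner, compound 3

A few compounds are considered here, and "the series" means these few. Any claim that something is new, unique, unknown or untested is made for them only; others in the source may bear on it.

In an ADME assay on microsomes from liver (Mus musculus) for metabolic stability, read by LC-MS, with a stated time of 30 min, tested at 1 uM (on this read-out higher numbers stand for a more stable compound and lower numbers for a less stable compound), compound 1 `O=C(NCc1ccc(S(=O)(=O)c2ccccc2)cc1)c1cc2ncccc2s1` gives 1.6%, while compound 2 `O=C(NCc1ccc(S(=O)(=O)c2ccccc2)cc1)c1c[nH]c2ccncc12` gives 45%, the higher of the two numbers. Among the measured compounds shown here, the only measured step, a number 43.4 percentage points higher from compound 1 to compound 2 (beyond the scatter), is large and beyond the scatter. Compound 3 `O=C(NCc1ccc(S(=O)(=O)c2ccccc2)cc1)c1cc2cnccc2[nH]1` has the same atoms as compound 2, joined differently: a group of 9 heavy atoms (7 carbon, 2 nitrogen; one five-membered aromatic ring with 1 hetero atom, one six-membered aromatic ring with 1 hetero atom) in place of a group of 9 heavy atoms (7 carbon, 2 nitrogen; one five-membered aromatic ring with 1 hetero atom, one six-membered aromatic ring with 1 hetero atom), on a carbonyl carbon. The measured step exchanged groups of different atom content, so it is only a loose guide here, and it suggests that the group on the carbonyl carbon can matter. A moderate fall is expected, a number 15 percentage points lower from compound 2 to compound 3 (beyond the scatter). For compound 3 the estimated value is 30%, with an expected range from 8% to 60%.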

Compound 3, percent of the compound remaining: 54%
For compound 3 the middle estimate is 24 percentage points below the measured one; the range from low to high includes it.
By their numbers in this assay, from the lowest: compound 1; then compounds 2 and 3 (each within the scatter of the next).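

On the carbonyl carbon, joining the same atoms differently gives a number 9 percentage points higher from compound 2 to compound 3 (within the scatter) in this assay, so this rearrangement separates neither group from the other. The exchange of the sulfur-containing group gives a number 52.4 percentage points higher from compound 1 to compound 3 (beyond the scatter), so the large step seen earlier is not tied to one arrangement of the two-nitrogen group. Nothing at hand explains these results. Still open, as far as these compounds go, is how a plain phenyl group on the carbonyl carbon would read, or a two-nitrogen group carrying an amine or a carboxylic acid.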